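From dimethylamino to a ring: compound 2 and compound 4

The source may report more compounds than this note shows. Statements on the series, on what has been measured and on what is new or still open speak of the compounds shown alone.

Compound 1 `O=C(NCc1ccc(Cl)cc1)c1ncc2cccnc2c1O`: > 50100 nM
Compound 2 `Cc1n[nH]c(-c2ncc3c(N(C)C)ccnc3c2O)n1`: > 50100 nM
Compound 3 `Cc1n[nH]c(-c2ncc3c(NCc4ccc(Cl)cc4)ccnc3c2O)n1`: > 50100 nM

In a toxicity assay on THP-1 cells (Homo sapiens) for cytotoxicity (a lower number here means that less compound is needed, a higher number that more compound is needed for the effect), compound 2 gives > 50100 nM, and this is a limit of the assay, not a number. All the measurements so far come down to the limit of > 50100 nM in this assay, at which 3 of the 3 values shown sit.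

Compound 4 `Cc1n[nH]c(-c2ncc3c(N4CCCCS4(=O)=O)ccnc3c2O)n1` differs from compound 2 on an aromatic carbon, opposite the ring nitrogen: a group of 8 heavy atoms (4 carbon, 1 nitrogen, 2 oxygen, 1 sulfur; one six-membered non-aromatic ring with 2 hetero atoms) in place of a group of 3 heavy atoms (2 carbon, 1 nitrogen; no ring), on an aromatic carbon. A six-membered non-aromatic ring with 2 hetero atoms takes the place of dimethylamino. Among the compounds with values here, no measured pair differs in one place only. The expected step of a number no higher from compound 2 to compound 4 (the limit leaves the size open) in this assay lies within the scatter, with no direction, because of the limit of > 50100 nM in this assay, at which 3 of the 3 values shown sit. For compound 4 the estimated value is 50100 nM, with an expected range of 25000 nM to 100000 nM.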

Compound 4, half-maximal effective concentration: > 50100 nM
Compound 4 gave a limit, no number; the forecaster's own chance of this, stated with the estimate: 80%; the middle value sits exactly at the limit.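

Compound 2 and compound 4 both end at a limit in this assay, so no step can be read between them: the limit of > 50100 nM in this assay, at which 4 of the 4 values shown sit.

The compounds shown leave open whether dimethylamino and the six-membered non-aromatic ring differ at all in this read-out.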